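A few compounds are considered here, and "the series" means these few. Any claim that something is new, unique, unknown or untested is made for them only; others in the source may bear on it.

Measured compounds and their values:

- compound 1, `CCCCNc1nc(N)nc(C)c1CCCN1CCCCC1`: 133 nM
- compound 2, `CCCCNc1nc(N)nc(C)c1CCCn1c(C)nc2ccccc21`: 366 nM
- compound 3, `CCCCNc1nc(N)nc(C)c1C#CCN1CCCCC1`: 3790 nM

All three were tested in an assay on HEK293 cells for agonist activity at Toll-like receptor 8 (Homo sapiens), read by spectrophotometry; a lower number here means that less compound is needed, a higher number that more compound is needed for the effect. Compound 1 has the lowest number of the three. Its nearest neighbour is compound 2, whose value sits beyond the usual scatter above it, and the furthest is compound 3, whose value lies well beyond the scatter above it. No pair among these three differs in just one place, so no single step between measured compounds can be read off; the values can only be set side by side.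

The unmeasured compound 4, `CCCCCc1c(C)nc(N)nc1NCCCC`, is reached from compound 1 by one change: ethyl in place of piperidin-1-yl on a saturated chain carbon, three bonds along the chain from an aromatic carbon. The shared core and the butylamino group stay as they are; only the end of the three-carbon chain changes.

Among the compounds with values here, with no measured step of this kind to lean on, the size of the effect is open. The expectation for compound 4 is a moderate rise in the number compared with compound 1, since the step of a 3.8-fold higher number from compound 1 to compound 4 (0.58 log units; beyond the scatter) seems more likely to cost than to gain, though a result within the scatter of compound 1 cannot be ruled out. Compound 4 is estimated at 500 nM in this assay, with a range from 100 nM to 2500 nM.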

Compound 4, half-maximal effective concentration: 1220 nM
Beside the measured number, compound 4's estimate is 2.4-fold (0.39 log units) below it; low and high end bracket the measured number.
By their numbers in this assay, from the lowest: compound 1; then compound 2; then compound 4; then compound 3.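

In this assay, within the data shown here, putting ethyl in place of piperidin-1-yl on a saturated chain carbon, three bonds along the chain from an aromatic carbon, gives a 9.2-fold higher number from compound 1 to compound 4 (0.96 log units; beyond the scatter), the first measured step at this position and one that lies beyond the usual scatter. The end of this chain therefore matters for the read-out: with the shared core and the butylamino group unchanged, more compound is needed once the piperidin-1-yl group is gone. Nothing available bears on why the number rises with this change.

The step removes the ring, the nitrogen and several heavy atoms all at once, so the compounds shown leave open which of these accounts for the rise. A cyclohexyl group at the same place would keep a six-membered ring without the nitrogen, a diethylamino group would keep the nitrogen without the ring, and comparing each with compound 1 and compound 4 would begin to pull these apart.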